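Moving a Chlorine on the Urea-Linked Aryl Ring

A few compounds are considered here, and "the series" means these few. Any claim that something is new, unique, unknown or untested is made for them only; others in the source may bear on it.

Within the data shown here, compound 1 `CCN1CCc2c(sc(NC(=O)Nc3cccc(Cl)c3Cl)c2C(N)=O)C1` gives 17400 nM in a functional assay (strain AB) with Danio rerio as the target, read by microscopy, with a stated time of 1 h (a higher number here means that more compound is needed for the effect, a lower number that less compound is needed), the higher of the two numbers known so far. In this assay compound 2 `C[N+]1(CC2CCCCC2)CCc2c(sc(NC(=O)Nc3ccc(Cl)cc3)c2C(N)=O)C1` gives 100 nM, a far lower number, yet it differs from compound 1 in several places, so the gap cannot be tied to any single change. Compound 3 `CCN1CCc2c(sc(NC(=O)Nc3ccc(Cl)cc3Cl)c2C(N)=O)C1` differs from compound 1 in one place: 2,4-dichlorophenyl in place of 2,3-dichlorophenyl on an amide-type nitrogen. Among the measured compounds shown here, with no single-change step measured, a modest move toward a lower number is expected, a 2.2-fold lower number from compound 1 to compound 3 (0.34 log units; beyond the scatter), and it may well fall within the usual scatter. Compound 3 is estimated at 8000 nM, with a range from 2000 nM to 30000 nM.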

Compound 3, half-maximal effective concentration: 11500 nM
For compound 3 the middle estimate is 1.4-fold (0.16 log units) below the measured one; the range from low to high includes it.
By their numbers in this assay, from the lowest: compound 2; then compounds 3 and 1 (each within the scatter of the next).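

In this assay, 2,4-dichlorophenyl in place of 2,3-dichlorophenyl on the amide-type nitrogen gives a 1.5-fold lower number from compound 1 to compound 3 (0.18 log units; within the scatter) and so the two compounds cannot be told apart. For this pair, then, moving one chlorine around the ring makes no clear difference to the amount of compound needed. No measurement here offers an explanation for this result.

Still open, from the compounds shown here alone, is whether a methoxy group or a trifluoromethyl group in place of the chlorines would move the number beyond the scatter. A plain phenyl ring at this nitrogen would show whether the chlorines matter at all.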